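The source may report more compounds than this note shows. Statements on the series, on what has been measured and on what is new or still open speak of the compounds shown alone.

Working notes on the series. Compound 1 `CN(C)CCn1cnnc1-c1cc(Oc2ccc(NC(=O)N/N=C/c3ccc(Cl)cc3Cl)cc2F)ccn1` and compound 2 `COc1cc(/C=N/NC(=O)Nc2ccc(Oc3ccnc(-c4nncn4CCN(C)C)c3)c(F)c2)cc(OC)c1OC` share one core and differ only in the aryl group on a carbon with a double bond to nitrogen. Within the data shown here, in a functional assay on HT-29 cells (Homo sapiens) for cytotoxicity, read by MTT assay, with a stated time of 72 h (on this read-out higher numbers stand for weaker inhibition and lower numbers for stronger inhibition), compound 1 gives 390 nM and compound 2 gives 3620 nM, the highest of the two numbers measured so far, with compound 1 the nearest neighbour. Among the measured compounds shown here, the single measured step is a 9.3-fold higher number from compound 1 to compound 2 (0.97 log units; beyond the scatter). Compound 3 `CN(C)CCn1cnnc1-c1cc(Oc2ccc(NC(=O)N/N=C/c3cccc(Cl)c3Cl)cc2F)ccn1` differs from compound 2 by 2,3-dichlorophenyl in place of 3,4,5-trimethoxyphenyl on a carbon with a double bond to nitrogen. For the measured compounds named here, this largely undoes the change that separates compound 1 from compound 2, except that compound 3 carries 2,3-dichlorophenyl where compound 1 carries 2,4-dichlorophenyl, and no measured step speaks to that difference. The expected step in this assay is therefore roughly the reverse of a 9.3-fold higher number from compound 1 to compound 2 (0.97 log units; beyond the scatter), toward a lower number. The estimated size is a 6.0-fold lower number from compound 2 to compound 3 (0.78 log units; beyond the scatter), with allowance for the changed chlorine pattern. Compound 3 is estimated at 600 nM, in a range of 200 nM to 2500 nM.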

Compound 3, half-maximal inhibitory concentration: 130 nM
Compound 3: middle estimate off by 4.6-fold (0.66 log units), on the high side; the whole stated range lies above it.
By their numbers in this assay, from the lowest: compound 3; then compound 1; then compound 2.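

The position on a carbon with a double bond to nitrogen responds not only to the exchange of 3,4,5-trimethoxyphenyl for a dichlorophenyl but also to where the two chlorines sit: in this assay, moving from 2,4-dichlorophenyl to 2,3-dichlorophenyl gives a step beyond the scatter (a 3.0-fold lower number from compound 1 to compound 3 (0.48 log units; beyond the scatter)). Among these compounds, the exchange of 3,4,5-trimethoxyphenyl for 2,3-dichlorophenyl gives the largest step so far (a 28-fold lower number from compound 2 to compound 3 (1.44 log units; beyond the scatter)), and both dichlorophenyl compounds give lower numbers than compound 2. No measurement available here explains either step.

The compounds shown leave open whether chlorine itself matters at this position or only the substitution pattern, which a 2,3-dimethoxyphenyl would help separate. A plain phenyl or a 3-chlorophenyl would show how much each chlorine contributes.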